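Hydroxyethyl in Place of Pentylphenyl on the Triazole

A few compounds are considered here, and "the series" means these few. Any claim that something is new, unique, unknown or untested is made for them only; others in the source may bear on it.

Measured compounds:
compound 1 `CCCCCc1ccc(-c2cn(C[C@H](O)[C@H]3OC(=O)C(OCc4ccccc4)=C3OCc3ccccc3)nn2)cc1` — 7460 nM
compound 2 `CC(C)(C)OC(=O)N1CCN(C(=S)SCc2cn(C[C@H](O)[C@H]3OC(=O)C(OCc4ccccc4)=C3OCc3ccccc3)nn2)CC1` — > 100000 nM

Of the compounds shown here, two with a shared core have been tested in a functional assay on HepG2 cells (Homo sapiens) for antiproliferative activity, read by MTT assay, with a stated time of 72 h; a lower number here means a stronger inhibitor, a higher number a weaker inhibitor. Among the measured compounds shown here, compound 1 is the only one that gives a number, 7460 nM. Compound 2 returns only a limit in this assay, > 100000 nM, and this is a limit rather than a measured value (the limit of > 100000 nM in this assay, at which 1 of the 2 values shown sits).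

Compound 3 `O=C1O[C@H]([C@@H](O)Cn2cc(CCO)nn2)C(OCc2ccccc2)=C1OCc1ccccc1` is now to be measured in this assay. Relative to compound 1 its change is 2-hydroxyethyl in place of 4-pentylphenyl on an aromatic carbon. For the measured compounds named here, no pair of measured compounds differing in a single place exists, so no measured step tells how far such a change reaches. Compound 3 is nonetheless expected to be a weaker inhibitor, with the step of a 5.4-fold higher number from compound 1 to compound 3 (0.73 log units; beyond the scatter) estimated to lie beyond the usual scatter. For compound 3 the expected value is 40000 nM, within a range from 10000 nM to 150000 nM, with a fair chance that only a limit is reported.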

Compound 3, half-maximal inhibitory concentration: 68100 nM
For compound 3 the middle estimate is 1.7-fold (0.23 log units) below the measured one; the range from low to high includes it.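

In this assay, among the compounds shown here, 2-hydroxyethyl in place of 4-pentylphenyl gives a 9.1-fold higher number from compound 1 to compound 3 (0.96 log units; beyond the scatter) and this is the first measured step at this aromatic carbon, showing that the group held there matters for the read-out. The change takes away the six-membered aromatic ring and goes from 11 heavy atoms to 3, yet compound 3 still gives a measured number, 68100 nM and not a limit. Compound 2, by contrast, returns only a limit, not a number: the limit of > 100000 nM in this assay, at which 1 of the 3 values shown sits.

The compounds shown leave open which part of the change carries the step: the loss of the aromatic ring, the shorter chain or the added hydroxyl. An unsubstituted phenyl, a plain pentyl chain or a 2-aminoethyl group at this carbon would begin to separate these.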